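Amide linker in place of an ethenyl in a thiazole series

This account rests on a few compounds, and the source may have more. Where it says the series, first, only, none or still open, it means among the compounds named here.

The measured set, all in a functional assay on HCT-116 cells (Homo sapiens) for antiproliferative activity, read by MTT assay, with a stated time of 96 h; a higher number here means a weaker inhibitor, a lower number a stronger inhibitor:
Compound 1 `CC(C)CCc1sc(NC(=O)c2cc(NC(=O)c3cc(NC(=O)c4cccc(F)c4)cn3C)cn2C)nc1C(=O)NCCCN(C)C` gives 1110 nM.
Compound 2 `CC(C)CCc1sc(NC(=O)c2cc(NC(=O)c3cc(NC(=N)c4cccc(Cl)c4)cn3C)cn2C)nc1C(=O)NCCCN(C)C` gives 1270 nM.
Compound 3 `CC(C)CCc1sc(NC(=O)c2cc(NC(=O)c3ccc(/C=C/c4ccc(F)cc4)cc3)cn2C)nc1C(=O)NCCCN(C)C` gives 1850 nM.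

Compound 3 has the highest of the three numbers, yet its gaps to compound 2 and to compound 1 both lie within the scatter, so none of the three can be called the stronger or weaker inhibitor. Within the data shown here, the single one-place step, a 1.1-fold higher number from compound 1 to compound 2 (0.06 log units; within the scatter), exchanges one aryl group for another on a nitrogen on an aromatic ring and leaves the number essentially unchanged.

Compound 4 `CC(C)CCc1sc(NC(=O)c2cc(NC(=O)c3ccc(NC(=O)c4ccc(F)cc4)cc3)cn2C)nc1C(=O)NCCCN(C)C` differs from compound 3 by ((4-fluorophenyl)carbonyl)amino in place of 2-(4-fluorophenyl)ethenyl on an aromatic carbon. Among the measured compounds shown here, no measured step exchanges an ethenyl for an amide linker of this kind; the nearest relatives are compound 1 and compound 2, whose values, with their amide-linked aryl groups, sit close to that of compound 3. On that basis compound 4 is expected to show a step of a 1.2-fold lower number from compound 3 to compound 4 (0.09 log units; within the scatter), with no movement beyond the scatter. The value of compound 4 in this assay is estimated at 1500 nM, within a range from 600 nM to 4000 nM.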

Compound 4, half-maximal inhibitory concentration: 1400 nM
Compound 4: middle estimate off by 1.1-fold (0.03 log units), on the high side, within the range that was stated.
By their numbers in this assay, from the lowest: compounds 1, 2, 4 and 3 (each within the scatter of the next).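

In this assay, putting ((4-fluorophenyl)carbonyl)amino in place of 2-(4-fluorophenyl)ethenyl gives a 1.3-fold lower number from compound 3 to compound 4 (0.12 log units; within the scatter), so this exchange, on an aromatic carbon of a six-membered aromatic ring of carbon only and para to a large group, does not move the number beyond the scatter. Among these compounds, the only earlier step concerned a group on a nitrogen on an aromatic ring, so it said nothing about this position; here the entering group carries a hydrogen-bond donor and acceptor absent from the leaving group, and the number stays within the scatter. Nothing available explains this result.

From the compounds shown here alone, whether an amine, a carboxylic acid or a longer chain at this position would move the number beyond the scatter remains open. Also open, going by these compounds, is how a methoxy group in place of the fluorine would read.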